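Replacing a Butyl Chain with a Methoxyphenyl Group

The source may hold more compounds than are shown below. What is called first, only, known or untested is meant among the compounds shown, and "the series" means these compounds.

Measured compounds:
compound 1, `CN1CCC[C@@H]1Cn1nc(Cc2ccc(O)cc2)c2ccccc2c1=O`: 251 nM
compound 2, `CN1CCC[C@@H]1Cn1nc(Cc2cccc(Cl)c2)c2ccccc2c1=O`: 398 nM
compound 3, `CCCCCc1nn(C[C@H]2CCCN2C)c(=O)c2ccccc12`: 501 nM

In an assay for binding affinity to Alpha-1A adrenergic receptor (Homo sapiens) (on this read-out higher numbers stand for weaker inhibition and lower numbers for stronger inhibition), compound 3 gives the highest of the three numbers, yet both a 1.3-fold higher number from compound 2 to compound 3 (0.10 log units; within the scatter) and a 2.0-fold higher number from compound 1 to compound 3 (0.30 log units; within the scatter) lie within the scatter, so no ordering among the three can be claimed.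

Compound 4, `COc1cccc(Cc2nn(C[C@H]3CCCN3C)c(=O)c3ccccc23)c1`, differs from compound 3 by 3-methoxyphenyl in place of butyl on a saturated chain carbon bound to an aromatic carbon. Among the compounds with values here, the steps that bear on this change are a 2.0-fold higher number from compound 1 to compound 3 (0.30 log units; within the scatter) and a 1.3-fold higher number from compound 2 to compound 3 (0.10 log units; within the scatter), each exchanging an aromatic group for butyl at the same place; read the other way they suggest at most a small drop in the number. Compound 4 is therefore expected to give about 350 nM, between 150 nM and 800 nM, a step of a 1.4-fold lower number from compound 3 to compound 4 (0.16 log units; within the scatter) that is not expected to exceed the scatter.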

Compound 4, inhibition constant: 1580 nM
Compound 4: middle estimate off by 4.5-fold (0.65 log units), on the low side, outside the stated range (above it).
By their numbers in this assay, from the lowest: compounds 1, 2 and 3 (each within the scatter of the next); then compound 4.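

In this assay, the three earlier compounds showed no step beyond the scatter at this saturated chain carbon bound to an aromatic carbon, but compound 4 does. Putting 3-methoxyphenyl in place of butyl gives a 3.2-fold higher number from compound 3 to compound 4 (0.50 log units; beyond the scatter), so an aromatic group here need not match butyl. Methoxy in place of chloro gives a 4.0-fold higher number from compound 2 to compound 4 (0.60 log units; beyond the scatter), and 3-methoxyphenyl in place of 4-hydroxyphenyl gives a 6.3-fold higher number from compound 1 to compound 4 (0.80 log units; beyond the scatter), so the substituent on the aromatic group counts.

No measurement at hand explains these steps. As far as these compounds go, whether an amine or a carboxylic acid in place of the methoxy would lower the number stays open.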